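A few compounds are considered here, and "the series" means these few. Any claim that something is new, unique, unknown or untested is made for them only; others in the source may bear on it.

Measured in a functional assay on HeLa cells (Homo sapiens) for antiproliferative activity, read by CCK-8 assay, with a stated time of 72 h; a lower number here means a stronger inhibitor, a higher number a weaker inhibitor:
Compound 1 `Cc1ccc(C(=O)Nc2cccc(-c3oc4cc(-c5ccc(F)cc5)ccc4c(=O)c3O)c2)cc1` gives 6190 nM.
Compound 2 `Cc1ccccc1C(=O)Nc1cccc(-c2oc3cc(-c4ccc(F)cc4)ccc3c(=O)c2O)c1` gives 11900 nM.
Compound 3 `COc1ccc(C(=O)Nc2cccc(-c3oc4cc(-c5ccc(F)cc5)ccc4c(=O)c3O)c2)c(F)c1` gives 16100 nM.

Compound 3 has the highest of the three numbers in this assay, so it is the weakest inhibitor measured here. Its distance to compound 2 is within the scatter; its distance to compound 1 is beyond it, as the step of a 2.6-fold higher number from compound 1 to compound 3 (0.42 log units; beyond the scatter) shows, while the step of a 1.4-fold higher number from compound 2 to compound 3 (0.13 log units; within the scatter) is small.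

Compound 4 `Cc1cc(C)cc(C(=O)Nc2cccc(-c3oc4cc(-c5ccc(F)cc5)ccc4c(=O)c3O)c2)c1` differs from compound 3 in one place: 3,5-dimethylphenyl in place of 2-fluoro-4-methoxyphenyl on a carbonyl carbon. The group that enters carries methyl groups, as do the groups in compound 1 and compound 2, and both of those compounds give lower numbers than compound 3. On that basis a modest move to a lower number is expected in this assay, about a 2.0-fold lower number from compound 3 to compound 4 (0.30 log units; within the scatter). For compound 4 the expected value is 8000 nM, with a likely range from 3500 nM to 18000 nM.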

Compound 4, half-maximal inhibitory concentration: 5540 nM
Estimate against measurement, compound 4: 1.4-fold (0.16 log units) above, within the range that was stated.
By their numbers in this assay, from the lowest: compounds 4, 1, 2 and 3 (each within the scatter of the next, the first and the last beyond it).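

In this assay, the new 3,5-dimethylphenyl group gives a 2.9-fold lower number from compound 3 to compound 4 (0.46 log units; beyond the scatter) and a 2.1-fold lower number from compound 2 to compound 4 (0.33 log units; beyond the scatter), both beyond the scatter. Against the single methyl group of the 4-methylphenyl, however, the result is a 1.1-fold lower number from compound 1 to compound 4 (0.05 log units; within the scatter), within the scatter, so having two methyl groups on this ring brings no measurable gain. Nothing available here explains these differences. The compounds shown leave open how an amine, a carboxylic acid or a longer chain on this ring would behave. They also leave open whether a single fluorine or a single methoxy group alone would shift the number.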